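The source may hold more compounds than are shown below. What is called first, only, known or untested is meant among the compounds shown, and "the series" means these compounds.

Measured so far:
compound 1 `ClCc1ccc(Cn2cnc3c(Cl)ncnc32)cc1` — 2230 nM
compound 2 `ClCc1ccc(Cn2cnc3nc(Cl)nc(Cl)c32)cc1` — 17400 nM
compound 3 `ClCc1ccc(Cn2cnc3c(Cl)nc(Cl)nc32)cc1` — 3470 nM

In a functional assay on COLO 205 cells (Homo sapiens) for cytotoxicity, read by sulforhodamine B assay, with a stated time of 48 h (on this read-out higher numbers stand for weaker inhibition of growth and lower numbers for stronger inhibition of growth), compound 2 gives the highest number of the three, beyond the scatter from both compound 3 and compound 1. Compound 4 `ClCc1ccc(Cn2cnc3ncnc(Cl)c32)cc1` has not yet been measured. Compound 2 and compound 3 carry the same atoms joined differently; the difference between the two cores is not broken down here.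

From compound 3 to compound 1 the change is hydrogen in place of chloro on an aromatic carbon, and it gave a 1.6-fold lower number from compound 3 to compound 1 (0.19 log units; within the scatter). The change from compound 2 to compound 4 is the same one: hydrogen in place of chloro on an aromatic carbon. The step expected from compound 2 to compound 4 is a 1.6-fold lower number from compound 2 to compound 4 (0.20 log units; within the scatter), set beside the earlier one because it rests only on a 1.6-fold lower number from compound 3 to compound 1 (0.19 log units; within the scatter), a single example of this change in the series. Compound 4 is therefore expected near 11000 nM, with a likely range from 5000 nM to 25000 nM.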

Compound 4, concentration for 50% growth inhibition: 1900 nM
Beside the measured number, compound 4's estimate is 5.8-fold (0.76 log units) above it, outside the stated range (below it).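

In this assay hydrogen in place of chloro on an aromatic carbon gave a 9.2-fold lower number from compound 2 to compound 4 (0.96 log units; beyond the scatter) and the step on one core did not predict the step on the other: the same change on two cores in this assay, a 1.6-fold lower number (0.19 log units; within the scatter) from compound 3 to compound 1 and a 9.2-fold lower number (0.96 log units; beyond the scatter) from compound 2 to compound 4, 5.9-fold (0.77 log units) apart, beyond the scatter of two such steps.
The size of this change therefore depends on the core that carries it, at least across these two pairs. With one pair on each core, this gives neither a reason for the difference nor a rule for any other core.

From the compounds shown here alone, whether an amine or a methoxy group on this same aromatic carbon would follow hydrogen or chloro remains open. Going by these compounds, all four compounds carry the chloromethyl group, so the effect of a hydroxymethyl group in its place also remains open.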